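The source may report more compounds than this note shows. Statements on the series, on what has been measured and on what is new or still open speak of the compounds shown alone.

Working notes on the series. Compound 1 (`COc1ccc(/C=C/C=C/C(=O)c2ccc(F)cc2)cc1`), compound 2 (`COc1ccc(/C=C/C=C/C(=O)c2ccc(C)cc2)cc1`), compound 3 (`COc1ccc(/C=C/C=C/C(=O)c2cc(C)oc2C)cc1`) and compound 4 (`COc1ccc(/C=C/C=C/C(=O)c2ccco2)cc1`) share one core and differ in the group on a carbonyl carbon. In an ADME assay on RAW264.7 cells (Mus musculus) for cytotoxicity, read by MTT assay (on this read-out lower numbers stand for stronger inhibition and higher numbers for weaker inhibition), compound 1 gives "not determined" (no result reported). In this assay compound 2 gives "not determined" (no result reported). In this assay compound 3 reads > 100000 nM, which is a limit and not a number. Compound 4 carries furan-2-yl in place of 2,5-dimethylfuran-3-yl on a carbonyl carbon. Going by the values given here, no measured step is available for scale. With only compound 3 and its limit of > 100000 nM as an anchor, no step beyond the scatter is expected in this assay. The expected change is a number no higher from compound 3 to compound 4 (the limit leaves the size open). For compound 4 the estimated value is 100000 nM, with an expected range of 30000 nM to 200000 nM.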

Compound 4, half-maximal inhibitory concentration: 76600 nM
For compound 4 the middle estimate is 1.3-fold (0.12 log units) above the measured one; low and high end bracket the measured number.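

In this assay, furan-2-yl in place of 2,5-dimethylfuran-3-yl on a carbonyl carbon gives an at least 1.3-fold lower number from compound 3 to compound 4 (0.11 log units; that floor lies within the scatter). Compound 4 thus gives this position its first single number, but the step shows no change beyond the scatter. From the compounds shown here alone, the true size of the step stays open because compound 3 is held only by a limit: the limit of > 100000 nM in this assay, at which 1 of the 4 values shown sits.

Going by these compounds, whether an amine or a carboxylic acid in place of furan-2-yl on a carbonyl carbon would move the number beyond the scatter remains open.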